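The source may report more compounds than this note shows. Statements on the series, on what has been measured and on what is new or still open speak of the compounds shown alone.

Of the compounds shown here, three sharing one core have been tested in an ADME assay on HEK-293T cells (Homo sapiens) for inhibition, read by CCK-8 assay, with a stated time of 48 h, tested at 20 uM; on this read-out higher numbers stand for more inhibition of growth at the one concentration tested and lower numbers for less inhibition of growth. Compound 1 `Cc1ccc(S(=O)(=O)Oc2ccccc2/C=C(\C#N)C(=O)Nc2nnc(Cc3cccc4ccccc34)s2)cc1` gives 23%, compound 2 `COc1ccc(S(=O)(=O)Oc2ccccc2/C=C(\C#N)C(=O)Nc2nnc(Cc3cccc4ccccc34)s2)cc1` gives 29%, and compound 3 `N#C/C(=C\c1ccccc1OS(=O)(=O)c1ccc(F)cc1)C(=O)Nc1nnc(Cc2cccc3ccccc23)s1` gives 15%. Compound 3 holds the lowest of the three numbers: the step of a number 8 percentage points lower from compound 1 to compound 3 (within the scatter) and the step of a number 14 percentage points lower from compound 2 to compound 3 (beyond the scatter) describe how far it sits from the other two.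

Compound 4 `N#C/C(=C\c1ccccc1OS(=O)(=O)c1ccc(F)cc1)C(=O)Nc1nnc(Cc2ccc(Cl)cc2)s1` has not yet been measured. It differs from compound 3 in one place: 4-chlorophenyl in place of naphthalen-1-yl on a saturated chain carbon bound to an aromatic carbon. All three measured steps, namely a number 6 percentage points higher from compound 1 to compound 2 (within the scatter), a number 8 percentage points lower from compound 1 to compound 3 (within the scatter) and a number 14 percentage points lower from compound 2 to compound 3 (beyond the scatter), swap one small group on an aromatic carbon in a different part of the molecule, and none of them touches the naphthalen-1-yl. Going by the values given here, no measured step therefore bears on this change, and the expectation can rest only on the value of compound 3 itself. The step from compound 3 to compound 4 is expected to be a number 1 percentage points higher from compound 3 to compound 4 (within the scatter), that is, no change beyond the usual scatter. Compound 4 is thus estimated at 16% in this assay, with a range from 3% to 32%.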

Compound 4, percent growth inhibition at one concentration: 14%
For compound 4 the middle estimate is 2 percentage points above the measured one; the range from low to high includes it.
By their numbers in this assay, from the lowest: compounds 4, 3, 1 and 2 (each within the scatter of the next, the first and the last beyond it).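

Going by these compounds alone, putting 4-chlorophenyl in place of naphthalen-1-yl on the saturated chain carbon gives a step of a number 1 percentage points lower from compound 3 to compound 4 (within the scatter) in this assay, the first reading at this position, since the earlier steps all lay elsewhere in the molecule. Here a group with one six-membered aromatic ring and 7 heavy atoms, one of them chlorine, cannot be told apart from a group with two such rings and 10 heavy atoms, so this part of the molecule tolerates this particular swap on this read-out. No measurement is available that would explain this result.

Going by these compounds, whether a group of another kind at this position, such as an amine, a carboxylic acid or a longer chain, would move the number beyond the scatter remains open. Also open, on these data alone, is whether this swap would read the same with methyl or methoxy in place of the fluoro group.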